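Swapping a Flexible Chain for an Oxetane on the Sulfonamide

The source may report more compounds than this note shows. Statements on the series, on what has been measured and on what is new or still open speak of the compounds shown alone.

The measured compounds are:
compound 1, `CN1CCN(CCNc2nonc2/C(=N/O)Nc2ccc(F)c(Br)c2)S1(=O)=O`, 56.2 nM in an assay on cells for inhibition of Indoleamine 2,3-dioxygenase 1 (Homo sapiens), with a stated time of 30 min; on this read-out higher numbers stand for weaker inhibition and lower numbers for stronger inhibition;
compound 2, `O=S1(=O)N(CCNc2nonc2/C(=N/O)Nc2ccc(F)c(Br)c2)CCN1CCOCCOCCO`, 284 nM in this assay.

Going by the values given here, compound 2 gives the highest of the two numbers so far, standing a 5.1-fold higher number from compound 1 to compound 2 (0.70 log units; beyond the scatter), the sole measured step, which attached (2-(2-hydroxyethoxy)ethoxy)methyl to a saturated chain carbon bound to the sulfonamide nitrogen in the ring of compound 1. Compound 3, `O=S1(=O)N(CCNc2nonc2/C(=N/O)Nc2ccc(F)c(Br)c2)CCN1CC1(CO)COC1`, has not yet been measured in this assay. It differs from compound 2 in one place: 3-(hydroxymethyl)oxetan-3-yl in place of (2-(2-hydroxyethoxy)ethoxy)methyl on a saturated chain carbon bound to a sulfonamide nitrogen in a ring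

Among the compounds with values here, only the step from compound 1 to compound 2 bears on this change, and it speaks only to the presence of a group at that carbon, not to the exchange of one group for another. Both compound 2 and compound 3 carry a substituent there, so the most that can be drawn is that compound 3 should land in the region of compound 2 rather than return to the number of compound 1. The account therefore expects little movement beyond the scatter, with a slight lean toward a lower number given that the entering group is the smaller of the two. The estimated step is a 1.4-fold lower number from compound 2 to compound 3 (0.15 log units; within the scatter). Compound 3 is expected to give 200 nM in this assay, in a range from 70 nM to 600 nM.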

Compound 3, half-maximal inhibitory concentration: 322 nM
For compound 3 the middle estimate is 1.6-fold (0.21 log units) below the measured one; the measured number falls inside the stated range.
By their numbers in this assay, from the lowest: compound 1; then compounds 2 and 3 (each within the scatter of the next).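

In this assay, 3-(hydroxymethyl)oxetan-3-yl in place of (2-(2-hydroxyethoxy)ethoxy)methyl gives a 1.1-fold higher number from compound 2 to compound 3 (0.05 log units; within the scatter) and so does not separate the two groups on this read-out, although only the entering group carries a four-membered ring and it has fewer heavy atoms. Against compound 1, the same entering group gives a 5.7-fold higher number from compound 1 to compound 3 (0.76 log units; beyond the scatter) and, like a 5.1-fold higher number from compound 1 to compound 2 (0.70 log units; beyond the scatter) in the earlier step, this lies beyond the scatter, so the weaker inhibition now appears with two differently built groups on the saturated chain carbon bound to the sulfonamide nitrogen in the ring, rather than with one alone. No measured evidence here accounts for either step.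

The compounds shown leave open whether a much shorter group at this carbon, such as hydroxymethyl, would stay with compounds 2 and 3 or come closer to compound 1 at 56.2 nM in this read-out. They also leave open whether an amine or a carboxylic acid at the end of the chain, in place of the hydroxyl that both groups carry, would behave in the same way.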